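This account rests on a few compounds, and the source may have more. Where it says the series, first, only, none or still open, it means among the compounds named here.

For the measured compounds named here, compound 3 `CC(C)c1nc(-c2ccc(F)cc2)c(/C=C/[C@@H]2C[C@@H](O)CC(=O)O2)c(C(C)C)n1` gives 3 nM in an assay for inhibition of 3-hydroxy-3-methylglutaryl-coenzyme A reductase (Rattus norvegicus) (a lower number here means a stronger inhibitor, a higher number a weaker inhibitor), the lowest of the three numbers measured so far. Compound 2 `Cc1cc(C)cc(-c2cc(-c3ccc(F)cc3)c(/C=C/[C@@H]3C[C@@H](O)CC(=O)O3)c(C(C)C)n2)c1` gives 8 nM in this assay, and compound 1 `Cc1cc(-c2ccc(F)cc2)c(/C=C/[C@@H]2C[C@@H](O)CC(=O)O2)c(C(C)C)n1` gives 9 nM; the gap from compound 3 to each of them lies beyond the scatter. Compound 4 `CC(C)c1nc(-c2ccccc2)nc(-c2ccc(F)cc2)c1/C=C/[C@@H]1C[C@@H](O)CC(=O)O1` differs from compound 3 by phenyl in place of isopropyl on an aromatic carbon. Going by the values given here, the one measured step that bears on such a change, a larger aromatic group entering in place of a small alkyl group on the shared core, is a 1.1-fold lower number from compound 1 to compound 2 (0.05 log units; within the scatter), which stayed within the scatter. On that basis no step beyond the scatter is expected, and compound 4 is estimated at 3 nM, with a range from 1 nM to 9 nM. That estimate corresponds to an expected step of no change at the digits printed from compound 3 to compound 4 (within the scatter).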

Compound 4, half-maximal inhibitory concentration: 3 nM
Estimate against measurement, compound 4: no gap at the digits printed; the measured number falls inside the stated range.
By their numbers in this assay, from the lowest: compounds 3 and 4 (each within the scatter of the next); then compounds 2 and 1 (each within the scatter of the next).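

Phenyl in place of isopropyl on the aromatic carbon between two ring nitrogen atoms gives no change at the digits printed from compound 3 to compound 4 (within the scatter) in this assay. The earlier step, a 1.1-fold lower number from compound 1 to compound 2 (0.05 log units; within the scatter), concerned a different core and a methyl group, so this result extends the same lack of a measurable shift to a second core and to isopropyl as the group replaced. On these data alone, whether an amine or a carboxylic acid at this position would also leave the number unchanged remains open. Nothing measured here explains why the number holds.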